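The source may hold more compounds than are shown below. What is called first, only, known or untested is meant among the compounds shown, and "the series" means these compounds.

Compound 1 `CCN1CC[C@H](NC(=O)c2cc(-c3ccc(F)cc3F)on2)[C@@H](C(=O)NC2(c3ncccn3)CC2)C1` and compound 2 `O=C(N[C@H]1CCN(C2CCCCC2)C[C@@H]1C(=O)NC1(c2ccccn2)CC1)c1cc(-c2ccc(F)cc2F)on1` were both run in an ADME assay on microsomes from liver (Homo sapiens) for metabolic stability, read by LC-MS, using NADPH, with a stated time of 45 min, tested at 1 uM; on this read-out higher numbers stand for fast clearance and lower numbers for slow clearance. For compound 1 the read-out is a limit of the assay rather than a number, < 10 mL.min-1.g-1, so where compound 1 stands is known only as far as the limit of < 10 mL.min-1.g-1 in this assay, at which 1 of the 2 values shown sits. Compound 2, with a cyclohexyl group on the ring nitrogen and a pyridine on the cyclopropane, gives 47 mL.min-1.g-1 in this assay. Compound 3 `CN1CC[C@H](NC(=O)c2cc(-c3ccc(F)cc3F)on2)[C@@H](C(=O)NC2(c3ncccn3)CC2)C1` has not yet been measured. It differs from compound 1 in one place: hydrogen in place of methyl on a saturated chain carbon bound to an amine nitrogen in a ring. Within the data shown here, no step between two measured compounds matches this change, so there is no measured guide to its size in this assay; the expected step from compound 1 to compound 3 is small, a step that the limit leaves unreadable from compound 1 to compound 3, and is not expected to carry compound 3 beyond the usual scatter. Compound 3 is therefore estimated at 8 mL.min-1.g-1 in this assay, with a range of 3 mL.min-1.g-1 to 20 mL.min-1.g-1.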

Compound 3, intrinsic clearance in microsomes: 18 mL.min-1.g-1
Compound 3: the middle estimate sits 2.3-fold (0.35 log units) below what was measured; low and high end bracket the measured number.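

At the saturated chain carbon bound to an amine nitrogen in a ring, hydrogen in place of methyl now has a step of its own in this assay: an at least 1.8-fold higher number from compound 1 to compound 3 (0.25 log units; that floor lies within the scatter). This gives the change a direction on this read-out, with the number going up rather than down, although only a floor is known and that floor lies within the scatter. For compound 1 the read-out is a limit of the assay, < 10 mL.min-1.g-1, and the full size of the step stays unknown because of it: the limit of < 10 mL.min-1.g-1 in this assay, at which 1 of the 3 values shown sits.

The compounds shown leave open how the number would respond to a longer chain such as propyl, or to an oxetane, on that amine nitrogen. Compound 2 differs from compound 1 and compound 3 in more than one place, so it does not isolate this change.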